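Shortening the side chain on an alkynyl ester scaffold

This account rests on a few compounds, and the source may have more. Where it says the series, first, only, none or still open, it means among the compounds named here.

Compound 1 `COC(=O)C#CC(CC(C)C)O/C=C/C(=O)OC`: 330 nM
Compound 2 `CCCCCCC(C#CC(=O)OC)O/C=C/C(=O)OC`: 2500 nM
Compound 3 `COC(=O)C#CC(O/C=C/C(=O)OC)C(C)(C)C`: 1800 nM

In a functional assay on HBL-100 cells (Homo sapiens) for antiproliferative activity, read by sulforhodamine B assay, with a stated time of 48 h (a higher number here means a weaker inhibitor of growth, a lower number a stronger inhibitor of growth), compound 3 stands second highest of the three numbers; its nearest neighbour is compound 2, within the scatter, while compound 1 lies furthest from it, as the step of a 5.5-fold higher number from compound 1 to compound 3 (0.74 log units; beyond the scatter) shows. Compound 4 `CCC(C#CC(=O)OC)O/C=C/C(=O)OC` differs from compound 3 by ethyl in place of tert-butyl on a saturated chain carbon bound to an oxygen on an unsaturated carbon and a triple-bonded carbon. Among the compounds with values here, two measured steps bear on this place: a 5.5-fold higher number from compound 1 to compound 3 (0.74 log units; beyond the scatter) and a 1.4-fold lower number from compound 2 to compound 3 (0.14 log units; within the scatter); the branched isobutyl gave the lowest number, while tert-butyl and hexyl were alike. The data give no direct reading for a short ethyl chain, so the expected step in this assay is small and uncertain. Compound 4 is therefore estimated at 900 nM (range 300 nM to 3000 nM), meaning an expected step of a 2.0-fold lower number from compound 3 to compound 4 (0.30 log units; within the scatter).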

Compound 4, concentration for 50% growth inhibition: 320 nM
Compound 4: the middle estimate sits 2.8-fold (0.45 log units) above what was measured; measured number inside the range.
By their numbers in this assay, from the lowest: compounds 4 and 1 (each within the scatter of the next); then compounds 3 and 2 (each within the scatter of the next).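

In this assay the short ethyl chain of compound 4 goes with the isobutyl chain of compound 1, not with tert-butyl or hexyl: a 5.6-fold lower number from compound 3 to compound 4 (0.75 log units; beyond the scatter) and a 7.8-fold lower number from compound 2 to compound 4 (0.89 log units; beyond the scatter) lie beyond the scatter, while a 1.0-fold lower number from compound 1 to compound 4 (0.01 log units; within the scatter) lies within it. A low number at this carbon therefore does not depend on the branching of isobutyl, and these four compounds do not follow chain length alone. Nothing shown here explains this pattern. As far as these compounds go, whether methyl, hydrogen or a propyl chain at this carbon would keep the number low stays open, as does the effect of a cyclopropyl ring.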